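The source may hold more compounds than are shown below. What is called first, only, known or untested is meant among the compounds shown, and "the series" means these compounds.

Measured in a functional assay on HL-60 cells (Homo sapiens) for cytotoxicity, read by ELISA, with a stated time of 2 days; a lower number here means a stronger inhibitor, a higher number a weaker inhibitor:
- compound 1 `Oc1cccc(-c2cc(-c3ccccc3)nc(-c3ccsc3)c2)c1`: 12000 nM
- compound 2 `Oc1cccc(-c2cc(-c3ccccc3)nc(-c3ccco3)c2)c1`: 24000 nM

In this assay, among the compounds with values here, compound 2, at 24000 nM, stands level with compound 1 within the scatter, the only other compound measured. Within the data shown here, the sole measured step, a 2.0-fold higher number from compound 1 to compound 2 (0.30 log units; within the scatter), exchanges thiophen-3-yl for furan-2-yl. Compound 3 `Oc1cccc(-c2cc(-c3ccccc3)nc(-c3ccccn3)c2)c1` carries pyridin-2-yl in place of furan-2-yl on an aromatic carbon. Among the measured compounds shown here, no measured step has a six-membered aromatic ring entering, so the evidence is thin, and no change beyond the scatter is expected. The expected step is a 1.5-fold lower number from compound 2 to compound 3 (0.18 log units; within the scatter). For compound 3 the estimated value is 16000 nM, with an expected range of 6000 nM to 40000 nM.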

Compound 3, half-maximal inhibitory concentration: 15100 nM
Beside the measured number, compound 3's estimate is 1.1-fold (0.03 log units) above it; the range from low to high includes it.
By their numbers in this assay, from the lowest: compounds 1, 3 and 2 (each within the scatter of the next).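

In this assay, pyridin-2-yl brings a six-membered aromatic ring to this place next to the ring nitrogen, giving a 1.6-fold lower number from compound 2 to compound 3 (0.20 log units; within the scatter) and also a 1.3-fold higher number from compound 1 to compound 3 (0.10 log units; within the scatter) in the comparison with thiophen-3-yl. Across these three aromatic rings, neither ring size nor the hetero atom moves the number beyond the scatter, so compounds 1, 2 and 3 stand level. No measurement shown here offers an explanation for this.

The compounds shown leave open whether any group at this place can move the number beyond the scatter. An amine, a carboxylic acid or a longer chain here remains untested in what is shown.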